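A few compounds are considered here, and "the series" means these few. Any claim that something is new, unique, unknown or untested is made for them only; others in the source may bear on it.

Working notes on the series. Compound 1 `O=C(NCc1ccc(CNS(=O)(=O)c2ccccc2F)cc1)c1cccnc1` and compound 2 `Cc1ccccc1C(=O)NCc1ccc(CNS(=O)(=O)c2cccc3ccccc23)cc1` share a core bearing an amide on one side and a sulfonamide on the other. In an assay on MDA-MB-231 cells for displacement of a labelled ligand from C-X-C chemokine receptor type 4 (Homo sapiens), read by fluorescence and microscopy, with stated times of 10 min and 30 min (a lower number here means that less compound is needed, a higher number that more compound is needed for the effect), compound 1 gives 100 nM, and in this assay compound 2 gives 100 nM; compound 2 stands level with compound 1 at the digits recorded, and its nearest neighbour in the data is compound 1, with no change beyond the scatter. Among the measured compounds shown here, no single-point step between measured compounds is available, so the size of a change at the sulfonyl sulfur cannot be read directly. Compound 3 `Cc1ccccc1C(=O)NCc1ccc(CNS(=O)(=O)c2ccccc2F)cc1` differs from compound 2 by 2-fluorophenyl in place of naphthalen-1-yl on a sulfonyl sulfur. Since compound 1 carries the same 2-fluorophenyl group and gives 100 nM, no shift beyond the scatter is expected, and the estimated step is no change at the digits printed from compound 2 to compound 3 (within the scatter). For compound 3 in this assay the expected value is 100 nM, with a range from 50 nM to 200 nM.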

Compound 3, effective concentration (reported as EC, without a stated level of effect): 1000 nM
Estimate against measurement, compound 3: 10-fold (1.00 log units) below; measured number outside the range, above it.
By their numbers in this assay, from the lowest: compounds 1 and 2 (each within the scatter of the next); then compound 3.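

In this assay, the group on the sulfonyl sulfur matters when 2-methylphenyl sits on the carbonyl carbon: 2-fluorophenyl in place of naphthalen-1-yl gives a 10-fold higher number from compound 2 to compound 3 (1.00 log units; beyond the scatter). The group on the carbonyl carbon matters as well when 2-fluorophenyl sits on the sulfonyl sulfur: 2-methylphenyl in place of pyridin-3-yl gives a 10-fold higher number from compound 1 to compound 3 (1.00 log units; beyond the scatter), so compound 3 links both places to a step beyond the scatter. Nothing at hand gives a reason for either step.

Going by these compounds, whether the step at the sulfonyl sulfur keeps its size with pyridin-3-yl on the carbonyl carbon remains open. Also open, on these data alone, is how unsubstituted phenyl or a carboxylic acid-bearing phenyl on the sulfonyl sulfur would compare with naphthalen-1-yl and 2-fluorophenyl.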